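Swapping a Methyl for Fluoro on the Benzyl Ring

The compounds below may be only part of what the source reports. "The series", "measured", "known", "first", "only" and "open" are said of these compounds alone.

Of the compounds shown here, two have been tested in an in vitro functional assay on cells for agonist activity at Bombesin receptor subtype-3 (Mus musculus), read by luminescence and calcium flux; on this read-out higher numbers stand for an effect only at larger amounts of compound and lower numbers for an effect already at smaller amounts. Compound 1 `CCCCc1cnc(C(C)Cc2ccc(-c3ccccc3C(=O)O)cc2)[nH]1` gives 184 nM. Compound 2 `Cc1ccccc1Cc1cnc(CCc2ccc(-c3ccccc3C(=O)O)cc2)[nH]1` gives 9.3 nM, the lowest of the two numbers, and its gap to compound 1 lies well beyond the scatter of repeated measurements.

Compound 3 `O=C(O)c1ccccc1-c1ccc(CCc2ncc(Cc3ccccc3F)[nH]2)cc1` is made from compound 2 by one change: fluoro in place of methyl on an aromatic carbon. Both the group that leaves and the group that enters are single heavy atoms, and neither ring nor hydrogen-bond donor or acceptor count is altered. For the measured compounds named here, no pair of measured compounds shows what such a swap does in this assay, so the step can only be expected to be small, at most modest, and in either direction, most likely staying within the scatter.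

The step from compound 2 to compound 3 is estimated at a 1.6-fold higher number from compound 2 to compound 3 (0.21 log units; within the scatter). Compound 3 is therefore expected to give about 15 nM, with a likely range from 5 nM to 45 nM.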

Compound 3, half-maximal effective concentration: 9.5 nM
Estimate against measurement, compound 3: 1.6-fold (0.20 log units) above, and the stated range covers the measured number.
By their numbers in this assay, from the lowest: compounds 2 and 3 (each within the scatter of the next); then compound 1.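

In this assay, the step is a 1.0-fold higher number from compound 2 to compound 3 (0.01 log units; within the scatter), so this read-out does not separate the 2-methylbenzyl group from the 2-fluorobenzyl group. This pair gives the first measured view of fluoro in place of methyl, and on this aromatic carbon, ortho to a large group, the swap leaves the two compounds indistinguishable within the scatter. No measurement at hand explains why the two groups read alike.

The compounds shown leave open how a larger group at the same place, such as methoxy or trifluoromethyl, would read, and whether a plain benzyl group, with only hydrogen there, would match them. They also leave open whether the same swap would read alike on other carbons of this ring, since a single pair describes a single place.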